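The source may report more compounds than this note shows. Statements on the series, on what has been measured and on what is new or still open speak of the compounds shown alone.

Measured compounds in a toxicity assay on THP-1 cells (Homo sapiens) for inhibition; on this read-out higher numbers stand for lower toxicity in this test and lower numbers for higher toxicity in this test:

compound 1, `Cn1c(-c2ccccc2)cnc1NC(=O)c1ccc(F)cc1`: in this assay compound 1 gives > 100000 nM, which is a limit of the assay and not a number.
compound 2, `Cc1cccc(C(=O)Nc2ncc(-c3ccccc3)n2C)c1`: in this assay compound 2 gives > 50000 nM, likewise a limit of the assay.

Going by the values given here, compound 1 thus stands only at a limit, and the one further value shown is a limit as well. The step that the two limits leave unreadable from compound 1 to compound 2 cannot be sized because the limit of > 100000 nM in this assay, at which 1 of the 2 values shown sits, and the limit of > 50000 nM in this assay, at which 1 of the 2 values shown sits, are both limits. Among the compounds with values here, no measured step therefore bears on the change from compound 1 to compound 3, whose structure is `Cn1c(-c2ccc(C#N)cc2)cnc1NC(=O)c1ccc(F)cc1`; the change is cyano in place of hydrogen on an aromatic carbon. With no readable step to draw on, compound 3 is expected to remain at the limit, and the step of a number no higher from compound 1 to compound 3 (the limit leaves the size open) is expected to stay within the scatter. Compound 3 is estimated at 100000 nM, with a range from 50000 nM to 200000 nM.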

Compound 3, half-maximal cytotoxic concentration: > 50000 nM
Compound 3: no number, only a limit (the forecaster's own chance of this, stated with the estimate: 80%); the middle value does not contradict the limit.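

In this assay compound 3 gives > 50000 nM, a limit of the assay and not a number. No step can be read between compound 1 and compound 3. The compounds shown leave open whether cyano in place of hydrogen changes the read-out in this assay at all, as none of them gives a number.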